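The compounds below may be only part of what the source reports. "The series", "measured", "known", "first", "only" and "open" are said of these compounds alone.

Among the measured compounds shown here, in an ADME assay on microsomes from liver (Mus musculus) for metabolic stability, with a stated time of 10 min (a lower number here means that less of the compound is left, a higher number that more of the compound is left), compound 1 `CC(=O)N1CCC(C(=O)N2CC[C@](c3ccc(C(F)(C(F)(F)F)C(F)(F)F)cc3)(S(=O)(=O)c3ccc(F)cc3)C2)CC1` stands as "not determined" (no result reported), so compound 2 `O=C(O)[C@H]1CC[C@H](C(=O)N2CC[C@](c3ccc(C(F)(C(F)(F)F)C(F)(F)F)cc3)(S(=O)(=O)c3ccc(Cl)cc3)C2)CC1`, at 100%, provides the only number available. Compound 3 `O=C(O)[C@H]1CC[C@H](C(=O)N2CC[C@](c3ccc(C(F)(C(F)(F)F)C(F)(F)F)cc3)(S(=O)(=O)c3ccc(F)c(C4CC4)c3)C2)CC1` differs from compound 2 at one place, with 3-cyclopropyl-4-fluorophenyl in place of 4-chlorophenyl on a sulfonyl sulfur. For the measured compounds named here, no measured pair shows the effect of such a change. With compound 2 at 100%, the expectation can hardly point upward. The expected step is a small fall, a number 10 percentage points lower from compound 2 to compound 3 (within the scatter), not clearly beyond the scatter. For compound 3 the estimate is 90%, with an expected range from 68% to 100%.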

Compound 3, percent of the compound remaining: 74%
Compound 3: the middle estimate sits 16 percentage points above what was measured, within the range that was stated.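

In this assay the group on the sulfonyl sulfur proves able to move the read-out: 3-cyclopropyl-4-fluorophenyl in place of 4-chlorophenyl gives a number 26 percentage points lower from compound 2 to compound 3 (beyond the scatter) and so shows that this position is not indifferent to such a change. Nothing measured here explains the fall. The step joins two differences within one group, the added cyclopropyl and fluorine in place of chlorine, and the compounds shown do not separate them. They also leave open how methyl in place of the cyclopropyl would read in this assay.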